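A Larger Group on the Ring Nitrogen of Compound 1

The source may hold more compounds than are shown below. What is called first, only, known or untested is meant among the compounds shown, and "the series" means these compounds.

Compound 1 `CCCCC#Cc1nc(NC2CC2)c2ncn([C@H]3[C@H](O)[C@H](O)[C@@H]4C[C@@H]43)c2n1` gives 19.8 nM in a functional assay on CHO cells for agonist activity at adenosine receptor A3 (Homo sapiens), read by scintillation counting and cAMP accumulation, with stated times of 45 min and 15 min, in the presence of a further agent that is not named here (a higher number here means that more compound is needed for the effect, a lower number that less compound is needed), and stands as the higher of the two numbers in hand. Compound 2 `CCCCC#Cc1nc(NCC)c2ncn([C@H]3[C@H](O)[C@H](O)[C@@H]4C[C@@H]43)c2n1` gives 15.5 nM in this assay. Among the compounds with values here, the only measured step, a 1.3-fold lower number from compound 1 to compound 2 (0.11 log units; within the scatter), leaves the two compounds within the scatter of one another, so no order can be read between them.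

Compound 3 `CCCCC#Cc1nc(NCc2cccc(F)c2)c2ncn([C@H]3[C@H](O)[C@H](O)[C@@H]4C[C@@H]43)c2n1` has not yet been measured. It differs from compound 1 by 3-fluorobenzyl in place of cyclopropyl on a nitrogen on an aromatic ring. Within the data shown here, the step from compound 1 to compound 2 touches the same nitrogen, but exchanges one small group for another and was within the scatter; the change to compound 3 brings in a considerably larger group, and no measured compound shows how such a group behaves at this place. Compound 3 is therefore expected to stay near compound 1, with a wide range allowed, and the step of a 1.3-fold lower number from compound 1 to compound 3 (0.12 log units; within the scatter) is estimated to lie within or close to the scatter. The estimate for compound 3 in this assay is 15 nM, with a range from 4 nM to 60 nM.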

Compound 3, half-maximal effective concentration: 18.9 nM
Compound 3: the middle estimate sits 1.3-fold (0.10 log units) below what was measured; measured number inside the range.
By their numbers in this assay, from the lowest: compounds 2, 3 and 1 (each within the scatter of the next).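

In this assay the exchange of cyclopropyl for 3-fluorobenzyl on the nitrogen on an aromatic ring gives a 1.0-fold lower number from compound 1 to compound 3 (0.02 log units; within the scatter) and so shows that this position accepts a group with an aromatic ring and considerably more heavy atoms with no readable difference in the number. Set against the ethyl compound, the same nitrogen substituent gives a 1.2-fold higher number from compound 2 to compound 3 (0.09 log units; within the scatter) and thus extends to a third group what the earlier pair showed for two small ones: across cyclopropyl, ethyl and 3-fluorobenzyl, no order can be read at this place in this assay. Nothing at hand accounts for this flat result, and no further data on these compounds bear on it.

From the compounds shown here alone, the share of the fluorine in the result of compound 3 stays open, as a plain benzyl group on the same nitrogen would be needed to separate it from that of the ring. Also open, going by these compounds, is whether the flat picture would hold for groups of another kind at this place, such as a longer chain like hexyl, or a benzyl group carrying a carboxylic acid or an amine.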